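Swapping methyl for isopropyl on a hydrazino-substituted thiadiazole

This account rests on a few compounds, and the source may have more. Where it says the series, first, only, none or still open, it means among the compounds named here.

Measured so far:
- compound 1, `COCN(N)c1nnc(-c2ccccc2Cl)s1`: 60 mg/kg
- compound 2, `CC(C)NNc1nnc(-c2ccccc2Cl)s1`: 50 mg/kg
- compound 3, `CNN(C)c1nnc(-c2ccccc2Cl)s1`: 25 mg/kg

All three compounds share one core and differ only in the hydrazine-type group attached to it. In a functional assay on the whole organism with Mus musculus as the target, with a stated time of 1 h (a higher number here means that more compound is needed for the effect, a lower number that less compound is needed), compound 3 gives the lowest of the three numbers, yet its lead over compound 2 is a 2.0-fold lower number from compound 2 to compound 3 (0.30 log units; within the scatter), and only its distance from compound 1, a 2.4-fold lower number from compound 1 to compound 3 (0.38 log units; beyond the scatter), is larger than usual scatter. So compound 3 is the best-looking compound here, but not clearly set apart from compound 2.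

Compound 4, `CNN(c1nnc(-c2ccccc2Cl)s1)C(C)C`, is the next step: isopropyl in place of methyl on a nitrogen on an aromatic ring. Going by the values given here, no measured pair shows exactly this exchange. The closest hint is compound 2, which carries an isopropyl on the outer nitrogen instead, and its step to compound 3 was a 2.0-fold lower number from compound 2 to compound 3 (0.30 log units; within the scatter). Compound 1 offers a less similar comparison, a 2.4-fold lower number from compound 1 to compound 3 (0.38 log units; beyond the scatter). Since a larger group on this part of the molecule has so far gone with a somewhat higher number, though not beyond the scatter, a small rise is the most reasonable expectation, with no change also plausible.

Compound 4 is therefore expected to give about 35 mg/kg in this assay, likely between 15 mg/kg and 80 mg/kg. The expected step is a 1.4-fold higher number from compound 3 to compound 4 (0.15 log units; within the scatter).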

Compound 4, dose for half-maximal effect: > 100 mg/kg
Compound 4 was reported as a limit; the forecaster's own chance of this, stated with the estimate: 5%; middle value at least 2.8-fold (0.45 log units) from the limit.
By their numbers in this assay, from the lowest: compounds 3, 2 and 1 (each within the scatter of the next, the first and the last beyond it). At a limit, above all of these: compound 4.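

Isopropyl in place of methyl on a nitrogen on an aromatic ring gives an at least 4.0-fold higher number from compound 3 to compound 4 (0.60 log units; beyond the scatter), the first step here that isolates this one nitrogen substituent and shows that the number can respond strongly to it, whereas compound 2, which carries its isopropyl as (isopropylamino)amino, stayed within the scatter of compound 3. The comparisons with the other two compounds are less decisive, since an at least 2.0-fold higher number from compound 2 to compound 4 (0.30 log units; that floor lies within the scatter) and an at least 1.6-fold higher number from compound 1 to compound 4 (0.22 log units; that floor lies within the scatter) both have floors that do not clear the scatter, so compound 4 cannot yet be firmly separated from either compound. Compound 4 gives > 100 mg/kg in this assay, and this is a limit of the assay rather than a number, so every step to it is only a floor: the limit of > 100 mg/kg in this assay, at which 1 of the 4 values shown sits.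

The compounds shown leave open how the number changes with an ethyl group or a longer chain on this nitrogen, and so whether the rise sets in gradually or only with isopropyl. They also leave open how far beyond its limit compound 4 really lies, and why this exchange has such an effect cannot be told from these values.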